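Methoxycarbonyl to Carbamoyl: A Small Step Expected

A few compounds are considered here, and "the series" means these few. Any claim that something is new, unique, unknown or untested is made for them only; others in the source may bear on it.

Compound 1 `COC(=O)c1ccc(-c2cnc(C(=O)CCc3ccc(-c4ccccc4)cc3)o2)nc1`: 2.2 nM
Compound 2 `CN(C)C(=O)c1cnc(C(=O)CCc2ccc(COc3ccccc3)cc2)o1`: 6.7 nM

In an assay for inhibition of Fatty-acid amide hydrolase 1 (Rattus norvegicus) (on this read-out higher numbers stand for weaker inhibition and lower numbers for stronger inhibition), compound 1 gives the lowest of the two numbers; compound 2 gives a higher number, a gap beyond the scatter. Compound 3 `NC(=O)c1ccc(-c2cnc(C(=O)CCc3ccc(-c4ccccc4)cc3)o2)nc1` carries amino in place of methoxy on a carbonyl carbon, that is, methoxycarbonyl to carbamoyl on the shared core. Among the compounds with values here, no measured pair shows this change, so the expectation rests on compound 1 alone. Compound 3 is expected to show a 1.4-fold higher number from compound 1 to compound 3 (0.13 log units; within the scatter), no step beyond the scatter. Compound 3 is therefore estimated at 3 nM, within a range from 1 nM to 10 nM.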

Compound 3, inhibition constant: 1.3 nM
Beside the measured number, compound 3's estimate is 2.3-fold (0.36 log units) above it; the range from low to high includes it.
By their numbers in this assay, from the lowest: compounds 3 and 1 (each within the scatter of the next); then compound 2.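

In this assay, within the data shown here, amino in place of methoxy on a carbonyl carbon gives a 1.7-fold lower number from compound 1 to compound 3 (0.23 log units; within the scatter), the first reading of any change at this position. The exchange of methoxycarbonyl for carbamoyl removes a hydrogen-bond acceptor and adds a hydrogen-bond donor, yet the read-out stays within the scatter. Nothing available accounts for this result. The compounds shown leave open how a carboxylic acid or a nitrile in place of the carbamoyl would read. They also leave open whether the same exchange would read alike on another core.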